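Benzylamine sulfonamides: tert-butyl to methoxy on the benzyl

This account rests on a few compounds, and the source may have more. Where it says the series, first, only, none or still open, it means among the compounds named here.

Measured so far:
compound 1 `CC(C)(C)c1ccc(CNCCCNS(=O)(=O)c2cc(C(F)(F)F)cc(C(F)(F)F)c2)cc1`, 2300 nM
compound 2 `O=[N+]([O-])c1ccc(S(=O)(=O)NCCCCCCNCc2ccc(Br)cc2)cc1`, 9800 nM
compound 3 `O=S(=O)(NCCCCCCNCc1ccc(Br)cc1)c1ccccc1F`, 13300 nM

In a functional assay on MIA PaCa-2 cells (Homo sapiens) for inhibition, read by MTT assay, with a stated time of 72 h (a higher number here means a weaker inhibitor of growth, a lower number a stronger inhibitor of growth), compound 1 gives the lowest of the three numbers; compound 2 sits well above it, and compound 3 further still, both gaps beyond the scatter. Among the measured compounds shown here, the one step between measured compounds, a 1.4-fold higher number from compound 2 to compound 3 (0.13 log units; within the scatter), concerns the aryl on the sulfonyl sulfur and lies within the scatter.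

Compound 4 `COc1ccccc1CNCCCNS(=O)(=O)c1cc(C(F)(F)F)cc(C(F)(F)F)c1` is not yet measured. It differs from compound 1 only on the benzyl side: 2-methoxyphenyl in place of 4-(tert-butyl)phenyl on a saturated chain carbon bound to an amine nitrogen. For the measured compounds named here, no measured pair changes this part of the molecule; compound 2 and compound 3 share a 4-bromobenzyl and differ elsewhere, so the step from compound 2 to compound 3 does not bear on the benzyl change. The expectation for compound 4 therefore rests on compound 1 alone, with wide uncertainty. Compound 4 is expected to give a somewhat higher number than compound 1, a step of about a 2.0-fold higher number from compound 1 to compound 4 (0.29 log units; within the scatter), which may not clear the scatter. The estimate for compound 4 in this assay is 4500 nM, with a range from 1500 nM to 14000 nM.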

Compound 4, concentration for 50% growth inhibition: 3100 nM
The estimate for compound 4 lay 1.5-fold (0.16 log units) above the measured number; low and high end bracket the measured number.
By their numbers in this assay, from the lowest: compounds 1 and 4 (each within the scatter of the next); then compounds 2 and 3 (each within the scatter of the next).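

In this assay, the benzyl side now has its first measured change: a 1.3-fold higher number from compound 1 to compound 4 (0.13 log units; within the scatter), so this pair gives no resolved difference between the 4-(tert-butyl)benzyl and 2-methoxybenzyl groups. The change replaces a group with no hydrogen-bond acceptor by one with 1 hydrogen-bond acceptor and alters both the substituent and its printed ring location, yet the read-out stays within the scatter, so at this position, on this shared core, both groups fit the same reading for this single pair. This holds for compound 1 and compound 4 only and cannot be extended to other benzyl groups, and nothing available explains the result.

A 4-methoxybenzyl group would separate the identity of the substituent from its location, and an unsubstituted benzyl group would show whether either substituent matters at all. Going by these compounds, compound 2 and compound 3 also differ from compound 1 in chain length and sulfonyl aryl as well as the benzyl group, so the effect of a 4-bromobenzyl group on the core of compound 1, or of a longer chain alone, remains open.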